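A few compounds are considered here, and "the series" means these few. Any claim that something is new, unique, unknown or untested is made for them only; others in the source may bear on it.

Compound 1 `CCOC(=O)C1=C(C)NC(COC)=C(C(=O)OC)C1c1cccc([N+](=O)[O-])c1` gives 14 nM in a functional assay on HEK293 cells for antagonist activity at Voltage-dependent L-type calcium channel subunit alpha-1C (Oryctolagus cuniculus), read by FLIPR; a higher number here means a weaker inhibitor, a lower number a stronger inhibitor. Compound 2 `CCOC(=O)C1=C(C)NC(C)=C(C(=O)OCCOC)C1c1cccc([N+](=O)[O-])c1` gives 16 nM. Compound 3 `COC(=O)C1=C(C)NC(C)=C(C(=O)OCCCl)C1c1cccc([N+](=O)[O-])c1` gives 26 nM.

Compound 3 has the highest number of the three, yet its gaps to compound 2 and to compound 1 both lie within the scatter, so the three values cannot be told apart. Compound 4 `COC(=O)C1=C(C)NC(C)=C(C(=O)OCCc2ccc(Cl)cc2)C1c1cccc([N+](=O)[O-])c1` is not yet measured; it differs from compound 3 in one place: 4-chlorophenyl in place of chloro on a saturated chain carbon, two bonds along the chain from an oxygen next to a carbonyl group. Within the data shown here, no step between measured compounds is known, so nothing points to a large shift. The step of a 1.7-fold lower number from compound 3 to compound 4 (0.24 log units; within the scatter) is expected to stay within the scatter, if anything toward a slightly lower number. Compound 4 is therefore estimated at 15 nM, with a range from 4 nM to 60 nM.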

Compound 4, half-maximal inhibitory concentration: 8 nM
Compound 4: middle estimate off by 1.9-fold (0.27 log units), on the high side; low and high end bracket the measured number.
By their numbers in this assay, from the lowest: compounds 4, 1, 2 and 3 (each within the scatter of the next, the first and the last beyond it).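

Among these compounds, replacing chloro with 4-chlorophenyl on this saturated chain carbon gives a 3.3-fold lower number from compound 3 to compound 4 (0.51 log units; beyond the scatter) in this assay, the first step in this set that clearly exceeds the scatter. This position therefore accepts a whole aromatic ring, seven heavy atoms in place of one, and the number falls rather than rises. Nothing measured here explains this step.

Still open, on these data alone, is whether the ring or its chlorine accounts for the change. A plain phenyl, a longer chain or an amine at this spot would help separate those possibilities.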